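The source may hold more compounds than are shown below. What is called first, only, known or untested is meant among the compounds shown, and "the series" means these compounds.

Measured so far in a functional assay on B16-F10 cells (Mus musculus) for antiproliferative activity, read by MTT assay, with a stated time of 48 h; a lower number here means a stronger inhibitor, a higher number a weaker inhibitor:
- compound 1 `Fc1ccc(NCc2cn(-c3ccccc3)nc2-c2ccc(Cl)cc2)cc1`: 2120 nM
- compound 2 `COc1ccc(-c2nn(-c3ccccc3)cc2CNc2ccc(F)cc2)cc1`: 6580 nM
- compound 3 `Cc1ccc(-c2nn(-c3ccccc3)cc2CNc2ccc(F)cc2)cc1`: 5670 nM

Compound 1 has the lowest number of the three, and both of its steps to the others lie beyond the scatter. The next compound to be tested is compound 4 `Clc1ccc(NCc2cn(-c3ccccc3)nc2-c2ccc(Cl)cc2)cc1`, and the change from compound 1 is chloro in place of fluoro on an aromatic carbon. In words, chloro takes the place of fluoro on an aromatic carbon, turning the 4-fluorophenyl group into 4-chlorophenyl.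

Going by the values given here, no measured step touches this group, since all three compounds carry 4-fluorophenyl. The evidence is therefore indirect and comes from the aromatic substituent elsewhere in the molecule. Replacing chloro with methoxy gives a 3.1-fold higher number from compound 1 to compound 2 (0.49 log units; beyond the scatter), and replacing chloro with methyl gives a 2.7-fold higher number from compound 1 to compound 3 (0.43 log units; beyond the scatter). The exchange of methoxy for methyl gives a 1.2-fold lower number from compound 2 to compound 3 (0.06 log units; within the scatter). Since the largest of these steps, a 3.1-fold higher number from compound 1 to compound 2 (0.49 log units; beyond the scatter), is only modest, and a single halogen exchange is a small change, no step beyond the scatter is expected in this assay, and no direction can be favoured with confidence.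

The estimate for the step is a 1.1-fold lower number from compound 1 to compound 4 (0.05 log units; within the scatter). For compound 4 the expected value is 1900 nM, with an estimated range of 850 nM to 4500 nM.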

Compound 4, half-maximal inhibitory concentration: 2450 nM
Compound 4: middle estimate off by 1.3-fold (0.11 log units), on the low side, within the range that was stated.
By their numbers in this assay, from the lowest: compounds 1 and 4 (each within the scatter of the next); then compounds 3 and 2 (each within the scatter of the next).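

Going by these compounds alone, on the 4-fluorophenyl group, para to a large group, compound 4 gives the first direct reading of this position in this assay: a 1.2-fold higher number from compound 1 to compound 4 (0.06 log units; within the scatter), so the exchange of fluoro for chloro cannot be told from the scatter. The earlier steps shown here changed only the substituent on the other aromatic ring, where a 3.1-fold higher number from compound 1 to compound 2 (0.49 log units; beyond the scatter) and a 2.7-fold higher number from compound 1 to compound 3 (0.43 log units; beyond the scatter) both lie beyond the scatter, and they said nothing about this site. Nothing at hand bears on why the two halogens read alike in this assay.

With only fluoro and chloro shown at this position, it remains open whether a larger or quite different group, such as trifluoromethyl, an amine or a carboxylic acid, would also leave the number within the scatter of compound 1 or would shift it. From the compounds shown here alone, it also remains open whether the fluoro to chloro exchange reads the same when the other aromatic ring carries methoxy or methyl, as in compound 2 and compound 3, in place of chloro.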